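Replacing carbamoyl by fluoro on the pendant phenyl ring

The source may report more compounds than this note shows. Statements on the series, on what has been measured and on what is new or still open speak of the compounds shown alone.

Compound 1 `C[C@H](Nc1nc(N)nc(N)c1C#N)c1c(C2CC2)c(=O)n2cc(F)ccc2c1-c1ccc(F)cc1`: 35%
Compound 2 `C[C@H](Nc1nc(N)nc(N)c1C#N)c1c(-c2ccccc2)c(=O)n2cc(F)ccc2c1C1CC1`: 84%
Compound 3 `C[C@H](Nc1nc(N)nc(N)c1C#N)c1c(-c2ccccc2)c(=O)n2cc(F)ccc2c1-c1ccc(C(N)=O)cc1`: 100%

Of the compounds shown here, three of the shared core have been measured in an ADME assay on microsomes from liver (Rattus norvegicus), read by LC-MS, using NADPH, with a stated time of 30 min, tested at 1 uM; a higher number here means that more of the compound is left, a lower number that less of the compound is left. Compound 1 gives 35%, compound 2 gives 84%, and compound 3 gives 100%. Compound 3 thus stands highest of the three; its nearest neighbour is compound 2, and the gap between them is beyond the scatter, while compound 1 lies far lower still.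

Within the data shown here, the only step measured in one place is a number 16 percentage points higher from compound 2 to compound 3 (beyond the scatter). Compound 4 `C[C@H](Nc1nc(N)nc(N)c1C#N)c1c(-c2ccccc2)c(=O)n2cc(F)ccc2c1-c1ccc(F)cc1` differs from compound 3 by fluoro in place of carbamoyl on an aromatic carbon. Among the measured compounds shown here, no measured step matches this exchange directly. The step from compound 2 to compound 3 shows that the group at this position can move this assay by a modest amount, and compound 1, which also carries a 4-fluorophenyl group though with cyclopropyl and the aryl group swapped, sits much lower than compound 3; that comparison is not a single-change step, so it only hints at the direction.

On this basis compound 4 is expected to show a modest drop, a number 25 percentage points lower from compound 3 to compound 4 (beyond the scatter), with the estimate for compound 4 at 75% and a range of 50% to 95%.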

Compound 4, percent of the compound remaining: 77%
Beside the measured number, compound 4's estimate is 2 percentage points below it; the range from low to high includes it.
By their numbers in this assay, from the lowest: compound 1; then compounds 4 and 2 (each within the scatter of the next); then compound 3.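

In this assay the exchange of carbamoyl for fluoro on the pendant ring can now be read directly as a number 23 percentage points lower from compound 3 to compound 4 (beyond the scatter) and it ties the carbamoyl group to a real difference in the percent of compound remaining. Set beside a number 16 percentage points higher from compound 2 to compound 3 (beyond the scatter) the step of a number 7 percentage points lower from compound 2 to compound 4 (within the scatter) shows that 4-fluorophenyl cannot be told apart from cyclopropyl at this position, so that of these three groups only 4-carbamoylphenyl stands apart. The other substituted position of the shared core also gets its first single-change reading, with a number 42 percentage points higher from compound 1 to compound 4 (beyond the scatter) when phenyl takes the place of cyclopropyl there, and this is the largest of the steps shown.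

The compounds shown leave open how a carboxylic acid, a primary amine or a methyl ester on the pendant ring would compare with carbamoyl and fluoro, and so whether the number of compound 3 is particular to carbamoyl. No evidence is at hand that explains any of these differences.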